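The source may hold more compounds than are shown below. What is called first, only, known or untested is meant among the compounds shown, and "the series" means these compounds.

In a functional assay on HCT-15 cells (Homo sapiens) for cytotoxicity, read by CCK-8 assay and cell counting, with a stated time of 2 days (a higher number here means a weaker inhibitor, a lower number a stronger inhibitor), the measured compounds are: compound 2 `Oc1ccc(-c2cc(-c3ccc(Cl)cc3)nc(-c3cccnc3)c2)cc1`, 20700 nM; compound 3 `Oc1ccc(-c2cc(-c3cccnc3)nc(-c3cccc(Cl)c3)c2)cc1`, 21300 nM. For compound 1 `Oc1cccc(-c2cc(-c3cccnc3)nc(-c3cccc(Cl)c3)c2)c1` the entry in this assay is "not determined" (no result reported), so compound 1 has no result reported.

For the measured compounds named here, compound 3 holds the higher of the two numbers, but the only measured step, a 1.0-fold higher number from compound 2 to compound 3 (0.01 log units; within the scatter), is within the scatter, so the two compounds are not distinguished by the data. Compound 4 `Oc1ccc(-c2cc(-c3ccccc3)nc(-c3cccc(Cl)c3)c2)cc1` differs from compound 3 by phenyl in place of pyridin-3-yl on an aromatic carbon. Going by the values given here, no measured step concerns this change: the single step available varies the chlorophenyl, not the pyridinyl, and stayed within the scatter. There is thus no basis for expecting a shift beyond the scatter, and the expected step is a 1.1-fold lower number from compound 3 to compound 4 (0.03 log units; within the scatter). Compound 4 is estimated at 20000 nM, with a range of 7000 nM to 55000 nM.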

Compound 4, half-maximal inhibitory concentration: 6100 nM
The estimate for compound 4 lay 3.3-fold (0.52 log units) above the measured number, and the stated range ends above it.
By their numbers in this assay, from the lowest: compound 4; then compounds 2 and 3 (each within the scatter of the next).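

In this assay the aryl group at this place, next to the ring nitrogen, moves the number: a 3.5-fold lower number from compound 3 to compound 4 (0.54 log units; beyond the scatter) follows from phenyl in place of pyridin-3-yl. For the compounds shown here, the chlorophenyl change gave only a 1.0-fold higher number from compound 2 to compound 3 (0.01 log units; within the scatter) and stayed within the scatter, so this is the first step beyond it, with the all-carbon ring on the stronger side. No measurement here bears on the reason for this step.

Going by these compounds, whether an amine or a carboxylic acid on this phenyl would shift the number further remains open. So does whether the step persists with 4-chlorophenyl in place of 3-chlorophenyl.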